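Swapping 2-chlorophenyl for 4-methylphenyl: permeability outlook

The compounds below may be only part of what the source reports. "The series", "measured", "known", "first", "only" and "open" are said of these compounds alone.

Measured compounds:
compound 1 `CNC(=O)c1cc(C(=O)N[C@H]2CC[C@H](O)CC2)c([C@@H](C)c2ccccc2Cl)o1`, 78 nm/s
compound 2 `CNC(=O)c1cc(C(=O)NC2CC2)n(Cc2ccccc2)n1`, > 80 nm/s

The two measured compounds were tested in an ADME assay for permeability; on this read-out higher numbers stand for higher permeability and lower numbers for lower permeability. Compound 1 gives 78 nm/s there. For compound 2 the assay reports only a limit, > 80 nm/s, and not a number; this is the point noted in the limit of > 80 nm/s in this assay, at which 1 of the 2 values shown sits. Among the compounds with values here, compound 1 therefore stands as the only value given as a number in this assay, with the one other value being a limit, so no measured step between compounds exists.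

Compound 3 `CNC(=O)c1cc(C(=O)N[C@H]2CC[C@H](O)CC2)c([C@@H](C)c2ccc(C)cc2)o1` has not yet been tested in this assay. It differs from compound 1 by 4-methylphenyl in place of 2-chlorophenyl on a saturated chain carbon bound to an aromatic carbon and a saturated chain carbon. Within the data shown here, with no measured step to draw on, the change is expected to shift the read-out by no more than the usual scatter, in no particular direction. Compound 3 is expected to give about 80 nm/s in this assay, within 40 nm/s to 160 nm/s, which means a step of a 1.0-fold higher number from compound 1 to compound 3 (0.01 log units; within the scatter).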

Compound 3, apparent permeability: 108 nm/s
The estimate for compound 3 lay 1.4-fold (0.13 log units) below the measured number; measured number inside the range.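

Within the data shown here, measured in this assay, 4-methylphenyl in place of 2-chlorophenyl on a saturated chain carbon bound to an aromatic carbon and a saturated chain carbon gives the first readable step at this place: a 1.4-fold higher number from compound 1 to compound 3 (0.14 log units; within the scatter). The earlier compounds shown here offered no such step, and this one shows that the read-out of the shared core stays within the scatter when one of these two aromatic groups replaces the other. No measured property shown here bears on this result.

Compound 2 is reported only as a limit and differs in more than one place, so steps involving it cannot be read. Still open, from the compounds shown here alone, is whether a phenyl ring carrying a carboxylic acid or an amine at this place would also stay within the scatter of compound 1.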